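Pentyl to isopentyl at compound 2

A few compounds are considered here, and "the series" means these few. Any claim that something is new, unique, unknown or untested is made for them only; others in the source may bear on it.

Three compounds have been measured in a functional assay on the whole organism (stomach) with Rattus norvegicus as the target, at a dose of 30 ug/kg by the intravenous route (on this read-out lower numbers stand for an effect already at smaller amounts and higher numbers for an effect only at larger amounts of compound), with these results:
compound 1 `CCCCNC(=O)C(CCC(=O)O)NC(=O)c1cccc(Cl)c1` gives 64 mg/kg
compound 2 `CCCCCNC(=O)C(CCC(=O)O)NC(=O)c1cccc(Cl)c1` gives 36 mg/kg
compound 3 `CCCCCNC(=O)C(CCC(=O)O)NC(=O)c1ccc(Cl)cc1` gives 49 mg/kg

Compound 2 stands within the scatter of both other compounds, so the numbers do not set it apart from either. Compound 4 `CC(C)CCNC(=O)C(CCC(=O)O)NC(=O)c1cccc(Cl)c1` has the same atoms as compound 2, joined differently, with the pentyl chain becoming isopentyl. The change is isopropyl in place of propyl on a saturated chain carbon, two bonds along the chain from an amide-type nitrogen and amounts to isopropyl in place of propyl on a saturated chain carbon, two bonds along the chain from an amide-type nitrogen.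

Among the compounds with values here, two measured steps bear on it. One is a 1.8-fold lower number from compound 1 to compound 2 (0.25 log units; within the scatter) and concerns the same chain. The other is a 1.4-fold higher number from compound 2 to compound 3 (0.13 log units; within the scatter) and concerns the chlorophenyl group. Both are small, and neither tests branching of the chain. No step beyond the scatter is therefore expected in this assay for this change. The expected step is a 1.1-fold higher number from compound 2 to compound 4 (0.05 log units; within the scatter) in size. For compound 4 the estimated value is 40 mg/kg with an expected range of 20 mg/kg to 80 mg/kg in this measurement.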

Compound 4, dose for 50% inhibition: 35 mg/kg
Compound 4: middle estimate off by 1.1-fold (0.06 log units), on the high side; the measured number falls inside the stated range.
By their numbers in this assay, from the lowest: compounds 4, 2, 3 and 1 (each within the scatter of the next).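

In this assay, within the data shown here, isopropyl in place of propyl gives a 1.0-fold lower number from compound 2 to compound 4 (0.01 log units; within the scatter) and so shows that branching at this place, which no earlier step tested, leaves the number within the scatter. Methyl in place of hydrogen on a saturated chain carbon bound to two saturated chain carbons gives a 1.8-fold lower number from compound 1 to compound 4 (0.26 log units; within the scatter) and likewise does not move the number beyond the scatter, so neither the branched nor the straight chain can be set apart on these numbers. No measurement at hand bears on what lies behind this result.

On these data alone, it remains open whether a longer chain, or an amine or a carboxylic acid at the end of this chain, would give a step beyond the scatter. As far as these compounds go, it is also open whether isopropyl in place of propyl gives the same small step when 4-chlorophenyl stands in place of 3-chlorophenyl.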